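This account rests on a few compounds, and the source may have more. Where it says the series, first, only, none or still open, it means among the compounds named here.

Measured in a functional assay on MCF7 cells (Homo sapiens) for inhibition, read by MTT assay, with a stated time of 48 h, tested at 10 uM; on this read-out higher numbers stand for more inhibition of growth at the one concentration tested and lower numbers for less inhibition of growth:
- compound 1 `Cc1cc(=O)c2c(O)c(CN3CCCC3)c(O)c([C@H]3CCN(C)C[C@H]3O)c2o1`: 12%
- compound 2 `Cc1cc(=O)c2c(O)c(CN(C)CC(=O)O)c(O)c([C@H]3CCN(C)C[C@H]3O)c2o1`: 27%

Of these two, compound 2 stands higher at 27%. Among the measured compounds shown here, the only measured step, a number 15 percentage points higher from compound 1 to compound 2 (beyond the scatter), is modest and replaces pyrrolidin-1-yl with (carboxymethyl)(methyl)amino.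

Compound 3 `Cc1cc(=O)c2c(O)c(CN3CC(O)CC3C(=O)O)c(O)c([C@H]3CCN(C)C[C@H]3O)c2o1` is next: 2-carboxy-4-hydroxypyrrolidin-1-yl in place of (carboxymethyl)(methyl)amino on a saturated chain carbon bound to an aromatic carbon. Here, 2-carboxy-4-hydroxypyrrolidin-1-yl takes the place of (carboxymethyl)(methyl)amino on a saturated chain carbon bound to an aromatic carbon. The entering group has a five-membered ring, as does the group in compound 1 (12%), and keeps a carboxy group, as in compound 2 (27%). A small fall, probably within the scatter, is therefore expected in this assay: the expected change is a number 5 percentage points lower from compound 2 to compound 3 (within the scatter). For compound 3 the estimated value is 22%, with an expected range of 9% to 38%.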

Compound 3, percent growth inhibition at one concentration: 25%
Beside the measured number, compound 3's estimate is 3 percentage points below it; the measured number falls inside the stated range.
By their numbers in this assay, from the lowest: compound 1; then compounds 3 and 2 (each within the scatter of the next).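

In this assay, a number 2 percentage points lower from compound 2 to compound 3 (within the scatter) shows that on a saturated chain carbon bound to an aromatic carbon, the open (carboxymethyl)(methyl)amino group and the ring-bearing 2-carboxy-4-hydroxypyrrolidin-1-yl cannot be told apart. Against the unsubstituted ring, a number 13 percentage points higher from compound 1 to compound 3 (beyond the scatter) shows that a five-membered ring at this place can also stand with the higher numbers, once it carries the carboxy and hydroxy groups. No measurement explains these results.

On these data alone, compound 3 adds carboxy and hydroxy together, so their separate shares remain open. A 3-hydroxypyrrolidin-1-yl or a 2-carboxypyrrolidin-1-yl group would separate them.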